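A few compounds are considered here, and "the series" means these few. Any claim that something is new, unique, unknown or untested is made for them only; others in the source may bear on it.

Measured compounds:
- compound 1, `Cc1cc(OCCCN2CCCC2=O)cc(C)c1-c1cccc(COc2ccc3c(c2)OC[C@H]3CC(=O)O)c1`: 170 nM
- compound 2, `Cc1nc(C)c(COc2cc(C)c(-c3cccc(COc4ccc5c(c4)OC[C@H]5CC(=O)O)c3)c(C)c2)s1`: 360 nM

In an assay on CHO cells for displacement of a labelled ligand from Free fatty acid receptor 1 (Rattus norvegicus), read by scintillation counting, with a stated time of 90 min, in the presence of a further agent that is not named here (a lower number here means a stronger inhibitor, a higher number a weaker inhibitor), compound 2 gives 360 nM, the higher of the two numbers recorded so far; compound 1 gives 170 nM. Among the compounds with values here, the one measured step, a 2.1-fold higher number from compound 1 to compound 2 (0.33 log units; beyond the scatter), trades a flexible chain ending in a lactam for an aromatic five-membered heterocycle on the saturated chain carbon bound to an oxygen on an aromatic ring.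

Compound 3, `CCS(=O)(=O)CCOc1cc(C)c(-c2cccc(COc3ccc4c(c3)OC[C@H]4CC(=O)O)c2)c(C)c1`, is not yet measured. It differs from compound 2 by (ethylsulfonyl)methyl in place of 2,4-dimethyl-1,3-thiazol-5-yl on a saturated chain carbon bound to an oxygen on an aromatic ring — (ethylsulfonyl)methyl in place of 2,4-dimethyl-1,3-thiazol-5-yl on a saturated chain carbon bound to an oxygen on an aromatic ring, so the ring is gone again and an open chain with two acceptors returns. Within the data shown here, the only bearing step is the modest one from compound 1 to compound 2; compound 3 reverses its ring-for-chain direction while keeping an acceptor-bearing tail, so a move back toward the number of compound 1 is expected rather than a large one either way. On that basis compound 3 is estimated at 220 nM in this assay, with a range from 90 nM to 550 nM. The expected step from compound 2 to compound 3 is therefore a 1.6-fold lower number from compound 2 to compound 3 (0.21 log units; within the scatter), near the edge of the scatter.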

Compound 3, inhibition constant: 170 nM
Compound 3: middle estimate off by 1.3-fold (0.11 log units), on the high side; measured number inside the range.
By their numbers in this assay, from the lowest: compounds 1 and 3 (each within the scatter of the next); then compound 2.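

In this assay, (ethylsulfonyl)methyl in place of 2,4-dimethyl-1,3-thiazol-5-yl on a saturated chain carbon bound to an oxygen on an aromatic ring gives a 2.1-fold lower number from compound 2 to compound 3 (0.33 log units; beyond the scatter) and shows that this position responds to a tail with no ring at all. Ethylsulfonyl in place of (2-oxopyrrolidin-1-yl)methyl gives no change at the digits printed from compound 1 to compound 3 (within the scatter) and so does not separate these two tails, which means the lactam ring of compound 1 is not required to reach the number it gives, while among these three compounds only compound 2, the one with an aromatic ring in the tail, stands apart. Nothing available accounts for either step.

As far as these compounds go, with a single aromatic tail in the set, it remains open whether the gap belongs to aromatic tails in general or to the 2,4-dimethyl-1,3-thiazol-5-yl group alone, and a phenyl or pyridine ring on the same carbon would bear on that. Also open, from the compounds shown here alone, is how far this tolerance for open chains extends, for example to a chain ending in a tertiary amine or a hydroxyl group.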